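From Nitrophenyl to Methoxyphenyl on the Chain of Compound 1

The source may hold more compounds than are shown below. What is called first, only, known or untested is meant among the compounds shown, and "the series" means these compounds.

Compound 1 `COc1ccc(C(=O)/C=C/c2cccc([N+](=O)[O-])c2)c2c1C=CC(C)(C)O2` is the reference point of this small set. In a functional assay on HT-29 cells (Homo sapiens) for antiproliferative activity, read by MTT assay, with a stated time of 24 h (a higher number here means a weaker inhibitor, a lower number a stronger inhibitor), compound 1 gives 4260 nM, the lowest of the two numbers reported. Compound 3 `COc1ccc(C(=O)/C=C/c2cccc(C(F)(F)F)c2)c2c1C=CC(C)(C)O2`, which carries a trifluoromethyl in place of nitro on an aromatic carbon, gives 9050 nM in this assay; the step of a 2.1-fold higher number from compound 1 to compound 3 (0.33 log units; beyond the scatter) is modest but beyond the scatter. Compound 2 `COc1ccc(C(=O)/C=C/c2ccc(OC)c(OC)c2OC)c2c1C=CC(C)(C)O2` reaches only a limit in this assay, > 10000 nM, as noted in the limit of > 10000 nM in this assay, at which 1 of the 3 values shown sits.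

Compound 4 `COc1ccccc1/C=C/C(=O)c1ccc(OC)c2c1OC(C)(C)C=C2` has not yet been measured. It differs from compound 1 as follows: 2-methoxyphenyl in place of 3-nitrophenyl on a double-bonded chain carbon bound to a double-bonded chain carbon. Among the measured compounds shown here, no measured step exchanges the whole aryl group, so the step from compound 1 to compound 3 is the only guide, and it ran toward a higher number. Compound 4 is therefore expected to sit somewhat higher than compound 1, with a 1.5-fold higher number from compound 1 to compound 4 (0.18 log units; within the scatter) as the estimated step. Compound 4 is estimated at 6500 nM in this assay, between 2500 nM and 15000 nM.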

Compound 4, half-maximal inhibitory concentration: > 10000 nM
Compound 4 was reported as a limit; the forecaster's own chance of this, stated with the estimate: 25%; middle value at least 1.5-fold (0.18 log units) from the limit.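

Among the compounds shown here, the exchange of 3-nitrophenyl for 2-methoxyphenyl on a double-bonded chain carbon bound to a double-bonded chain carbon is the first step here that replaces the whole aryl group, and in this assay it gives an at least 2.3-fold higher number from compound 1 to compound 4 (0.37 log units; beyond the scatter). Together with a 2.1-fold higher number from compound 1 to compound 3 (0.33 log units; beyond the scatter), this means that both steps read at this position now run away from compound 1 toward a higher number. Compound 4 joins compound 2 at a limit of the assay, so both compounds with methoxy on this aryl group give no number: the limit of > 10000 nM in this assay, at which 2 of the 4 values shown sit.

The compounds shown leave open whether the rise follows from losing the nitro group or from gaining the methoxy group. They also leave open how an amine or a carboxylic acid on this aryl group would compare with compound 1.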